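Working notes: from compound 2 to compound 3

The compounds below may be only part of what the source reports. "The series", "measured", "known", "first", "only" and "open" are said of these compounds alone.

Measured in a functional assay on MCF7 cells (Homo sapiens) for cytotoxicity; a lower number here means a stronger inhibitor, a higher number a weaker inhibitor:
compound 1 `C=C/C=C\[C@H](C)[C@H](OC(N)=O)[C@@H](C)[C@H](O)[C@@H](C)C/C(C)=C\[C@H](C)[C@@H](O)[C@@H](C)/C=C\CCc1ccc(C)c(F)c1` gives 4000 nM
compound 2 `C=C/C=C\[C@H](C)[C@H](OC(N)=O)[C@@H](C)[C@H](O)[C@@H](C)C/C(C)=C\[C@H](C)[C@@H](O)[C@@H](C)/C=C\CCc1cccc(O)c1C` gives 1000 nM

Compound 2 holds the lower of the two numbers in this assay and so far is the stronger inhibitor. Among the measured compounds shown here, the one measured step (a 4.0-fold lower number from compound 1 to compound 2 (0.60 log units; beyond the scatter)) lies beyond the scatter, but it swaps the fluoro for a hydroxy and moves the methyl at once, so it does not separate the two changes.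

Compound 3 `C=C/C=C\[C@H](C)[C@H](OC(N)=O)[C@@H](C)[C@H](O)[C@@H](C)C/C(C)=C\[C@H](C)[C@@H](O)[C@@H](C)/C=C\CCc1ccc(C)c(O)c1` has the same atoms as compound 2, joined differently (3-hydroxy-4-methylphenyl in place of 3-hydroxy-2-methylphenyl on a saturated chain carbon, two bonds along the chain from a double-bonded chain carbon). The change sits on a saturated chain carbon, two bonds along the chain from a double-bonded chain carbon. The 3-hydroxy-4-methylphenyl of compound 3 keeps the hydroxy of compound 2 and takes the methyl placement of compound 1, so part of that measured step may return. A modest rise is expected (a 1.6-fold higher number from compound 2 to compound 3 (0.20 log units; within the scatter)) and may stay near the scatter. The estimate for compound 3 is an expected 1600 nM (range 500 nM to 5000 nM).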

Compound 3, half-maximal inhibitory concentration: 4000 nM
Estimate against measurement, compound 3: 2.5-fold (0.40 log units) below, within the range that was stated.
By their numbers in this assay, from the lowest: compound 2; then compounds 1 and 3 (each within the scatter of the next).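

In this assay, the step with the hydroxy held and only the methyl placement altered is a 4.0-fold higher number from compound 2 to compound 3 (0.60 log units; beyond the scatter) and stands beyond the scatter, so the arrangement of the ring on this saturated chain carbon counts even with the same atoms present. With the methyl placement held, hydroxy in place of fluoro gives no change at the digits printed from compound 1 to compound 3 (within the scatter) and does not register in this ring, so among these compounds the lower number goes with 3-hydroxy-2-methylphenyl and not with the hydroxy alone. No data at hand bear on the reason for this difference.

The compounds shown leave open whether the hydroxy contributes at all within 3-hydroxy-2-methylphenyl, or whether a methoxy or an amine in its place would keep the number of compound 2. Also open, going by these compounds, is how a longer chain than 2-(3-hydroxy-2-methylphenyl)ethyl would read.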